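Compound 3 to compound 4: an aryl exchange

A few compounds are considered here, and "the series" means these few. Any claim that something is new, unique, unknown or untested is made for them only; others in the source may bear on it.

In a functional assay on THP-1 cells (Homo sapiens) for cytotoxicity, read by MTT assay, with a stated time of 24 h (on this read-out higher numbers stand for weaker inhibition and lower numbers for stronger inhibition), compound 1 (`COc1ccc(/C=C2\CN(C)C/C(=C\c3ccccc3F)C2=O)cc1`) gives 15400 nM, compound 2 (`COc1ccc(/C=C2\CN(C)C/C(=C\c3ccccc3F)C2=O)cc1OC`) gives 11200 nM and compound 3 (`COc1cc(/C=C2\CN(C)C/C(=C\c3ccc(F)cc3)C2=O)cc(OC)c1`) gives 5040 nM, the lowest of the three numbers and beyond the scatter of both others. Compound 4 (`COc1cc(/C=C2\CN(C)C/C(=C\c3ccc(Cl)c(Cl)c3)C2=O)cc(OC)c1`) has 3,4-dichlorophenyl in place of 4-fluorophenyl on a double-bonded chain carbon bound to a double-bonded ring carbon. Among the compounds with values here, no measured step covers this exchange. Within the data shown here, the only measured step, a 1.4-fold lower number from compound 1 to compound 2 (0.14 log units; within the scatter), is methoxy in place of hydrogen on an aromatic carbon, so it sets no direction in this assay, and no step beyond the scatter is expected. The estimated step is a 1.3-fold lower number from compound 3 to compound 4 (0.10 log units; within the scatter). For compound 4 the expected value is 4000 nM, with an estimated range of 1500 nM to 10000 nM.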

Compound 4, half-maximal inhibitory concentration: 3260 nM
Compound 4: middle estimate off by 1.2-fold (0.09 log units), on the high side; low and high end bracket the measured number.
By their numbers in this assay, from the lowest: compounds 4 and 3 (each within the scatter of the next); then compounds 2 and 1 (each within the scatter of the next).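

Within the data shown here, this is the only step at the double-bonded chain carbon bound to a double-bonded ring carbon, and it reads a 1.5-fold lower number from compound 3 to compound 4 (0.19 log units; within the scatter) in this assay. At this place, 3,4-dichlorophenyl and 4-fluorophenyl are therefore not told apart on the shared core of compound 3 and compound 4. No supporting measurement bears on this result.

From the compounds shown here alone, it remains open whether a phenyl carrying an amine or a carboxylic acid at this place would stay within the scatter of compound 3. Going by these compounds, it is also open whether the same aryl exchange would read alike on the core of compound 2.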